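Moving the Methyl Group from Compound 3 to Compound 4

This account rests on a few compounds, and the source may have more. Where it says the series, first, only, none or still open, it means among the compounds named here.

In a functional assay on SMMC-7721 cells (Homo sapiens) for cytotoxicity, read by MTT assay, with a stated time of 72 h (on this read-out lower numbers stand for stronger inhibition and higher numbers for weaker inhibition), compound 1 `O=C(CSC(=S)N[C@H]1CCOC1=O)Nc1ccccc1F` gives > 128000 nM as a limit of the assay. Compound 3 `Cc1cccc(NC(=O)CSC(=S)N[C@H]2CCOC2=O)c1` gives > 128000 nM which is likewise only a limit. Among the measured compounds shown here, compound 2 `O=C(CSC(=S)N[C@H]1CCOC1=O)Nc1ccc(Br)cc1` gives 28300 nM as the one true number here. For the measured compounds named here, two steps bear on what follows, an at least 4.5-fold lower number from compound 1 to compound 2 (0.65 log units; beyond the scatter) and an at least 4.5-fold higher number from compound 2 to compound 3 (0.65 log units; beyond the scatter) and both lie beyond the scatter. Compound 4 `Cc1ccc(NC(=O)CSC(=S)N[C@H]2CCOC2=O)cc1` differs through 4-methylphenyl in place of 3-methylphenyl on an amide-type nitrogen with 4-methylphenyl in place of 3-methylphenyl on an amide-type nitrogen. Compound 2 also carries its group as a 4-substituted phenyl and gives 28300 nM so a modest gain is the expectation. An estimated at least 1.8-fold lower number from compound 3 to compound 4 (0.26 log units; that floor lies within the scatter) is expected toward a lower number. Compound 4 is estimated at 70000 nM with an expected range from 25000 nM to 180000 nM in this reading.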

Compound 4, half-maximal inhibitory concentration: 32700 nM
Compound 4: the middle estimate sits 2.1-fold (0.33 log units) above what was measured; the measured number falls inside the stated range.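

Two compounds with the same atoms separate on the methyl's place alone: 4-methylphenyl in place of 3-methylphenyl on an amide-type nitrogen gives an at least 3.9-fold lower number from compound 3 to compound 4 (0.59 log units; beyond the scatter). Methyl in place of bromo on an aromatic carbon gives a 1.2-fold higher number from compound 2 to compound 4 (0.06 log units; within the scatter), and 4-methylphenyl in place of 2-fluorophenyl gives an at least 3.9-fold lower number from compound 1 to compound 4 (0.59 log units; beyond the scatter). The steps from compound 3 and compound 1 are floors only, since both compounds rest on a limit: the limit of > 128000 nM in this assay, at which 2 of the 4 values shown sit.

As far as these compounds go, it remains open whether an amine, a carboxylic acid or a longer chain in place of that methyl would keep this read-out.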